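The source may report more compounds than this note shows. Statements on the series, on what has been measured and on what is new or still open speak of the compounds shown alone.

Measured so far in a functional assay on HeLa cells (Homo sapiens) for cytotoxicity, read by WST assay, with a stated time of 48 h; on this read-out higher numbers stand for weaker inhibition and lower numbers for stronger inhibition:

- Compound 1 `COc1cc(C(c2ccc(O)c(OC)c2)[C@@H](C)[C@@H](C)CO)ccc1O` gives > 100000 nM as a limit of the assay
- Compound 2 `COc1cc(C(c2ccc(O)c(OC)c2)[C@H](C)C(C)C)ccc1O` gives 16000 nM
- Compound 3 `COc1cc(C(c2ccc(O)c(OC)c2)[C@@H](C)[C@@H](C)CF)ccc1O` gives 42000 nM

Of the two values that are not limits, compound 3 stands at 42000 nM as the higher one. Compound 4 `COC[C@@H](C(C)C)C(c1ccc(O)c(OC)c1)c1ccc(O)c(OC)c1` differs from compound 3 by one change on a saturated chain carbon bound to two aromatic carbons (1-(methoxymethyl)-2-methylpropyl in place of 2-(fluoromethyl)-1-methylpropyl on a saturated chain carbon bound to two aromatic carbons). Within the data shown here, two measured steps bear on it, and both are modest: a 2.6-fold higher number from compound 2 to compound 3 (0.42 log units; beyond the scatter) for the change of side chain and an at least 2.3-fold lower number from compound 1 to compound 3 (0.37 log units; beyond the scatter) for fluoro in place of hydroxy. On these sizes, no step beyond the scatter is expected in this assay. The expected step is a 1.2-fold lower number from compound 3 to compound 4 (0.08 log units; within the scatter) on this estimate. Compound 4 is estimated at 35000 nM with an expected range from 14000 nM to 90000 nM.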

Compound 4, half-maximal inhibitory concentration: 69000 nM
Beside the measured number, compound 4's estimate is 2.0-fold (0.29 log units) below it; the measured number falls inside the stated range.
By their numbers in this assay, from the lowest: compound 2; then compounds 3 and 4 (each within the scatter of the next). At a limit, above all of these: compound 1.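

In this assay, 1-(methoxymethyl)-2-methylpropyl on a saturated chain carbon bound to two aromatic carbons gives a 1.6-fold higher number from compound 3 to compound 4 (0.22 log units; within the scatter) in place of 2-(fluoromethyl)-1-methylpropyl, so this change does not separate the two chains. In place of 1,2-dimethylpropyl it gives a 4.3-fold higher number from compound 2 to compound 4 (0.63 log units; beyond the scatter) as a step, so a second chain besides that of compound 3 also stands beyond the scatter from compound 2. Compound 1 gives a limit, not a number, so an at least 1.4-fold lower number from compound 1 to compound 4 (0.16 log units; that floor lies within the scatter) sets only a floor: the limit of > 100000 nM in this assay, at which 1 of the 4 values shown sits.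

As far as these compounds go, whether an amine or a carboxylic acid on this chain would bring the number under that of compound 2 stays open. So does the effect of a longer chain.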